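Amide aryl swap on the flavonol series: bromophenyl to methylphenyl

A few compounds are considered here, and "the series" means these few. Any claim that something is new, unique, unknown or untested is made for them only; others in the source may bear on it.

Three amides on a shared flavonol core have been measured in a functional assay on HCC1937 cells (Homo sapiens) for antiproliferative activity, read by CCK-8 assay, with a stated time of 72 h; on this read-out higher numbers stand for weaker inhibition and lower numbers for stronger inhibition. Compound 1 `O=C(Nc1cccc(-c2oc3cc(-c4ccc(F)cc4)ccc3c(=O)c2O)c1)c1ccc(Cl)cc1` gives 4030 nM. Compound 2 `Cc1ccccc1C(=O)Nc1cccc(-c2oc3cc(-c4ccc(F)cc4)ccc3c(=O)c2O)c1` gives 9900 nM. Compound 3 `O=C(Nc1cccc(-c2oc3cc(-c4ccc(F)cc4)ccc3c(=O)c2O)c1)c1ccc(Br)cc1` gives 8630 nM. Within the data shown here, on these numbers compound 3 sits with compound 2 at the upper end of the set; the two differ only within the scatter, and the one step from compound 3 that is beyond the scatter is the one to compound 1, which has a lower number.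

The next compound, compound 4 `Cc1cccc(C(=O)Nc2cccc(-c3oc4cc(-c5ccc(F)cc5)ccc4c(=O)c3O)c2)c1`, is reached from compound 3 by 3-methylphenyl in place of 4-bromophenyl on a carbonyl carbon. Among the measured compounds shown here, two measured steps bear on this. Replacing a halophenyl by a methylphenyl is seen in a 2.5-fold higher number from compound 1 to compound 2 (0.39 log units; beyond the scatter), a modest rise. The reverse direction, methylphenyl back to halophenyl, is seen in a 1.1-fold lower number from compound 2 to compound 3 (0.06 log units; within the scatter), which stays within the scatter. For completeness, a 2.1-fold higher number from compound 1 to compound 3 (0.33 log units; beyond the scatter) shows the chloro-to-bromo step alone. Methyl-bearing and bromo-bearing amides have thus so far given numbers close to one another, and the new methyl position has no measured precedent. The expectation in this assay is therefore a step near a 1.0-fold higher number from compound 3 to compound 4 (0.02 log units; within the scatter), without a clear direction beyond the scatter.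

Compound 4 is estimated at 9000 nM, with a range from 3500 nM to 22000 nM.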

Compound 4, half-maximal inhibitory concentration: 8030 nM
For compound 4 the middle estimate is 1.1-fold (0.05 log units) above the measured one; the range from low to high includes it.
By their numbers in this assay, from the lowest: compounds 1, 4, 3 and 2 (each within the scatter of the next, the first and the last beyond it).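

Moving the methyl on the amide aryl ring does not separate the two isomers in this assay: 3-methylphenyl in place of 2-methylphenyl gives a 1.2-fold lower number from compound 2 to compound 4 (0.09 log units; within the scatter) and leaves both methyl-bearing amides at the same level. Compound 4 also cannot be told apart from the bromo amide, with a 1.1-fold lower number from compound 3 to compound 4 (0.03 log units; within the scatter) for 3-methylphenyl in place of 4-bromophenyl, so this swap on the carbonyl carbon gives no readable change in this assay. With a 2.0-fold higher number from compound 1 to compound 4 (0.30 log units; within the scatter), compound 4 is also not separated from the 4-chlorophenyl amide, so compound 1 now stands clear of compounds 2 and 3 only, and no supporting data bear on the reason for these numbers.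

Going by these compounds, whether a 4-methylphenyl, an unsubstituted phenyl or an aryl ring carrying an amine or a carboxylic acid on this carbonyl carbon would move the number beyond the scatter from these four compounds remains open. The shared core is identical throughout, so these compounds say nothing about how a change there, such as a chloro in place of the fluoro, would compare with changes at the amide.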